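This account rests on a few compounds, and the source may have more. Where it says the series, first, only, none or still open, it means among the compounds named here.

Measured in a functional assay on MCF7 cells (Homo sapiens) for antiproliferative activity, read by MTT assay, with a stated time of 72 h; on this read-out lower numbers stand for stronger inhibition and higher numbers for weaker inhibition:
- Compound 1 `C=C1CN/C(=N/c2ccccc2)S1`: > 100000 nM, a limit of the assay.
- Compound 2 `COc1ccc(/C=C2/CN(C)/C(=N/c3ccc(C(C)(C)C)cc3)S2)cc1`: 28700 nM.
- Compound 3 `C=C1CN(C)/C(=N/c2ccccc2)S1`: > 100000 nM, a limit of the assay.

Compound 2 gives the only number shown. Compound 1 and compound 3 share (the limit of > 100000 nM in this assay, at which 2 of the 3 values shown sit).

Compound 4 `COc1ccc(/C=C2/CN(C)/C(=N/c3ccc(C(F)(F)F)cc3)S2)cc1` is not yet measured. It differs from compound 2 by trifluoromethyl in place of tert-butyl on an aromatic carbon. Within the data shown here, the one measured step, a step that the two limits leave unreadable from compound 1 to compound 3, concerns a different place and gives no size to carry over. No direction can therefore be drawn for this assay, and no shift beyond the scatter is expected. The expected change is a 1.0-fold higher number from compound 2 to compound 4 (0.02 log units; within the scatter). Compound 4 is estimated at 30000 nM, with an expected range of 10000 nM to 90000 nM.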

Compound 4, half-maximal inhibitory concentration: 24100 nM
Compound 4: the middle estimate sits 1.2-fold (0.10 log units) above what was measured; the range from low to high includes it.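

Trifluoromethyl in place of tert-butyl on an aromatic carbon gives the first readable step of the series, since the earlier step between two limits cannot be read. In this assay it amounts to a 1.2-fold lower number from compound 2 to compound 4 (0.08 log units; within the scatter), so the two groups cannot be told apart at this place. No measured property available here bears on this step.

As far as these compounds go, what an amine or a carboxylic acid would give on this aromatic carbon stays open. So does whether any replacement of tert-butyl here can shift the number beyond the scatter.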